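The source may hold more compounds than are shown below. What is called first, only, known or untested is meant among the compounds shown, and "the series" means these compounds.

Compound 1, `Nc1nc(Cl)c2ncn(C3CCC(CO)C3)c2n1`, and compound 3, `Nc1nc(Cl)c2nnn(C3CCC(CO)C3)c2n1`, share a chloro group and a primary amine on a fused two-ring core but differ in the core itself; the difference between the two cores is not broken down here. In a functional assay on P388 cells (Mus musculus) for inhibition (on this read-out higher numbers stand for an effect only at larger amounts of compound and lower numbers for an effect already at smaller amounts), compound 1 gives > 100 ug/mL, which is a limit of the assay rather than a number. For the measured compounds named here, compound 3 gives 18 ug/mL in this assay, the only real number among the three values measured so far.

Compound 2, `Nc1nc(O)c2ncn(C3CCC(CO)C3)c2n1`, arises from compound 1 by the change (hydroxy in place of chloro on an aromatic carbon). In this assay compound 2 gives > 100 ug/mL, again a limit and not a number. The step that the two limits leave unreadable from compound 1 to compound 2 therefore cannot be sized: both ends sit at the limit, as the limit of > 100 ug/mL in this assay, at which 2 of the 3 values shown sit, records.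

Going by the values given here, compound 4, `Nc1nc(O)c2nnn(C3CCC(CO)C3)c2n1`, is the not yet measured partner of compound 3, reached by the change (hydroxy in place of chloro on an aromatic carbon); this is the same change as the one from compound 1 to compound 2, at the same place on the core. Among the compounds with values here, only one example of it has been measured, and that one gives no readable size, so the expectation for compound 4 rests on compound 3 with its value 18 ug/mL. It rests also on the weight of the measured values recorded in the limit of > 100 ug/mL in this assay, at which 2 of the 3 values shown sit. A step of a 3.9-fold higher number from compound 3 to compound 4 (0.59 log units; beyond the scatter) toward weaker activity is estimated for compound 4 from compound 3. Compound 4 is accordingly estimated at 70 ug/mL in this assay, between 15 ug/mL and 150 ug/mL.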

Compound 4, concentration for half-maximal effect: 51 ug/mL
Beside the measured number, compound 4's estimate is 1.4-fold (0.14 log units) above it, within the range that was stated.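

In this assay, putting hydroxy in place of chloro on the core of compound 3 gives a 2.8-fold higher number from compound 3 to compound 4 (0.45 log units; beyond the scatter), so on this core the change has a readable size and moves the number toward weaker activity. For the compounds shown here, on the core of compound 1, the same change leads to compound 2, but that step cannot be read because neither compound gives a real number, only a limit of the assay: the limit of > 100 ug/mL in this assay, at which 2 of the 4 values shown sit. The result therefore shows that the change can cost some activity on one core, but it does not show that the size, or even the direction, carries over from one core to the other, since only one of the two steps can be read and a single step makes no rule for the series.

A fair comparison between the cores would need a pair on the core of compound 1 in which both members give real numbers, and the compounds shown contain no such pair. They also leave open what an amine or a methoxy group would give in place of chloro on that aromatic carbon, on either core.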